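The source may hold more compounds than are shown below. What is called first, only, known or untested is meant among the compounds shown, and "the series" means these compounds.

The measured compounds:

Compound 1, `COc1cc(-c2ccnc3cc(-c4ccccc4)nn23)cc(OC)c1OC`, gives 3880 nM in a functional assay on HCT-116 cells (Homo sapiens) for inhibition, read by CCK-8 assay, with a stated time of 48 h; on this read-out higher numbers stand for weaker inhibition and lower numbers for stronger inhibition.
Compound 2, `COc1cc(-c2ccnc3cc(-c4ccc5cnn(C)c5c4)nn23)cc(OC)c1OC`, gives 2440 nM in this assay.
Compound 3, `COc1cc(-c2ccnc3cc(-c4ccc(C)c(C)c4)nn23)cc(OC)c1OC`, gives 261 nM in this assay.

Compound 3 holds the lowest number of the three. Its nearest neighbour is compound 2, with a step of a 9.3-fold lower number from compound 2 to compound 3 (0.97 log units; beyond the scatter), and the wider gap is a 15-fold lower number from compound 1 to compound 3 (1.17 log units; beyond the scatter). The step of a 1.6-fold lower number from compound 1 to compound 2 (0.20 log units; within the scatter) stays within the scatter.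

Compound 4, `COc1cc(-c2ccnc3cc(-c4cccc(C)c4)nn23)cc(OC)c1OC`, has not yet been measured. It differs from compound 3 by hydrogen in place of methyl on an aromatic carbon; cut one bond further out, the same difference reads 3,4-dimethylphenyl to 3-methylphenyl.

The step that bears on this change is a 15-fold lower number from compound 1 to compound 3 (1.17 log units; beyond the scatter), where both methyl groups enter together onto the phenyl of compound 1. Compound 4 keeps one of the two, so it is expected to sit between compound 1 and compound 3 in this assay, with a number higher than that of compound 3 but not as high as that of compound 1. For compound 4 the expected step is a 3.4-fold higher number from compound 3 to compound 4 (0.54 log units; beyond the scatter), a rise beyond the scatter. Compound 4 is therefore estimated at 900 nM, within a range from 350 nM to 2500 nM.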

Compound 4, half-maximal inhibitory concentration: 6150 nM
Beside the measured number, compound 4's estimate is 6.8-fold (0.83 log units) below it; the measured number lies above the stated range.
By their numbers in this assay, from the lowest: compound 3; then compounds 2, 1 and 4 (each within the scatter of the next, the first and the last beyond it).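

Going by these compounds alone, the earlier compounds showed the two methyl groups only entering together, whereas in this assay the step of a 24-fold higher number from compound 3 to compound 4 (1.37 log units; beyond the scatter) shows that taking away the single methyl group on this carbon, ortho to a methyl group and para to a large group, is enough to lose that advantage, and the step of a 1.6-fold higher number from compound 1 to compound 4 (0.20 log units; within the scatter) leaves 3-methylphenyl not separable from plain phenyl. The methyl group that stays in compound 4 therefore brings no measurable gain by itself, and the step of a 2.5-fold higher number from compound 2 to compound 4 (0.40 log units; beyond the scatter) puts 3-methylphenyl on the side of weaker inhibition relative to 1-methyl-1H-indazol-6-yl. Nothing available explains why this one methyl group matters so much in the presence of the other.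

The compounds shown leave open whether a 4-methylphenyl group, with a methyl group on this carbon alone, would come close to compound 3 or whether both methyl groups are needed together. Going by these compounds, it also stays open whether a methoxy group, a chlorine atom or a longer chain such as ethyl on this same carbon could take the place of the methyl group.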